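The source may report more compounds than this note shows. Statements on the series, on what has been measured and on what is new or still open speak of the compounds shown alone.

Three compounds have been measured in a functional assay on HCT-116 cells (Homo sapiens) for antiproliferative activity, read by CCK-8 assay, with a stated time of 72 h, tested at 8 uM; a lower number here means a weaker effect, a higher number a stronger effect of the compound at the concentration tested:

compound 1 `CN1CCN(c2nc(Cl)nc3c2ncn3Cc2ccc(C(=O)Nc3ccccc3N)cc2)CC1` gives 72.8%;
compound 2 `CC(C)n1cnc2c(Nc3cccc(Cl)c3)nc(NCOCc3ccc(C(=O)Nc4ccccc4N)cc3)nc21` gives 63.4%;
compound 3 `Nc1ccccc1NC(=O)/C=C/c1ccc(Cn2cnc3c(Nc4cccc(Cl)c4)nc(Cl)nc32)cc1` gives 15.8%.

Compound 3 stands lowest of the three numbers. Its nearest neighbour is compound 2, whose number is higher by more than the usual scatter, and compound 1 lies further away still, also beyond the scatter. Compound 4 `Nc1ccccc1NC(=O)/C=C/c1ccc(Cn2cnc3c(Nc4ccccc4)nc(Cl)nc32)cc1` has not yet been measured. It differs from compound 3 in one place: hydrogen in place of chloro on an aromatic carbon. For the measured compounds named here, no pair of measured compounds differs by this kind of change, so there is no measured step to lean on. The change removes only a single chloro. The number in this assay is expected to move little, with no step beyond the scatter. Compound 4 is therefore estimated at 14%, within 0% to 35%, which means an expected step of a number 1.8 percentage points lower from compound 3 to compound 4 (within the scatter).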

Compound 4, a percentage reported as inhibition, at one concentration (the size of the read-out at that concentration, not a potency): 30.9%
For compound 4 the middle estimate is 16.9 percentage points below the measured one; low and high end bracket the measured number.
By their numbers in this assay, from the lowest: compound 3; then compound 4; then compounds 2 and 1 (each within the scatter of the next).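

In this assay the change from chloro to hydrogen gives a number 15.1 percentage points higher from compound 3 to compound 4 (beyond the scatter) and so shows that this one place on the ring responds to the loss of a single chloro, with the phenyl form ahead of the 3-chlorophenyl form. Nothing available explains this step. 

Going by these compounds, whether a fluoro, methyl or methoxy group at the same place would land nearer compound 3 or compound 4 stays open. So does whether the same change would act alike in compound 2, which also carries the (3-chlorophenyl)amino group.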